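From 4-Methylphenyl to 3-Hydroxyphenyl on the Triazole

A few compounds are considered here, and "the series" means these few. Any claim that something is new, unique, unknown or untested is made for them only; others in the source may bear on it.

Three esters of a shared core have been tested in a functional assay on DU-145 cells (Homo sapiens) for antiproliferative activity, read by MTT assay, with a stated time of 48 h; on this read-out lower numbers stand for stronger inhibition and higher numbers for weaker inhibition. There, compound 1 `C#CCOC(=O)/C(C)=C/CC/C(C)=C/CC/C(C)=C/CC[C@@H]1[C@@]2(C)CCC(=O)C(C)(C)[C@H]2CC[C@@]1(C)O` gives 46100 nM, and compound 2 `COc1ccc(-n2cc(COC(=O)/C(C)=C/CC/C(C)=C/CC/C(C)=C/CC[C@@H]3[C@@]4(C)CCC(=O)C(C)(C)[C@H]4CC[C@@]3(C)O)nn2)cc1` gives 135000 nM. Compound 3 `C/C(=C\CC/C(C)=C/CC[C@@H]1[C@@]2(C)CCC(=O)C(C)(C)[C@H]2CC[C@@]1(C)O)CC/C=C(\C)C(=O)OCc1cn(-c2ccc(C)cc2)nn1` gives > 150000 nM, which is a limit of the assay and not a number.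

Compound 4 `C/C(=C\CC/C(C)=C/CC[C@@H]1[C@@]2(C)CCC(=O)C(C)(C)[C@H]2CC[C@@]1(C)O)CC/C=C(\C)C(=O)OCc1cn(-c2cccc(O)c2)nn1` has 3-hydroxyphenyl in place of 4-methylphenyl on an aromatic nitrogen. Among the compounds with values here, two measured steps bear on this change. Exchanging the ethynyl group for the 1-(4-methylphenyl)-1H-1,2,3-triazol-4-yl group produced an at least 3.2-fold higher number from compound 1 to compound 3 (0.51 log units; beyond the scatter). The closer precedent is the exchange of methoxy for methyl on the aromatic ring, which produced an at least 1.1-fold higher number from compound 2 to compound 3 (0.04 log units; that floor lies within the scatter). Since this second step alters only the aromatic substituent, the new exchange is expected to produce no step beyond the scatter, although the limit on compound 3 leaves the size uncertain. The expected change is an at least 1.1-fold lower number from compound 3 to compound 4 (0.06 log units; that floor lies within the scatter). Compound 4 is estimated at 130000 nM, with an expected range of 55000 nM to 280000 nM.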

Compound 4, half-maximal inhibitory concentration: 28400 nM
Beside the measured number, compound 4's estimate is 4.6-fold (0.66 log units) above it; measured number outside the range, below it.
By their numbers in this assay, from the lowest: compounds 4 and 1 (each within the scatter of the next); then compound 2. At a limit, above all of these: compound 3.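

On the aromatic nitrogen of the five-membered ring, the choice of aryl group now matters in this assay: 3-hydroxyphenyl in place of 4-methylphenyl gives an at least 5.2-fold lower number from compound 3 to compound 4 (0.72 log units; beyond the scatter), and in place of 4-methoxyphenyl it gives a 4.8-fold lower number from compound 2 to compound 4 (0.68 log units; beyond the scatter), whereas methyl for methoxy had shown no step beyond the scatter. Compound 3 stands at a limit of the assay and not at a number, so the first of these steps is only a floor: the limit of > 150000 nM in this assay, at which 1 of the 4 values shown sits. With 3-hydroxyphenyl, the large ester group no longer stands apart from ethynyl, as the exchange gives a 1.6-fold lower number from compound 1 to compound 4 (0.21 log units; within the scatter).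

The compounds shown change the ring substituent and its place together, so they leave open whether the hydroxyl or its location carries the step. 4-Hydroxyphenyl, 3-methoxyphenyl and 3-aminophenyl groups on the same nitrogen would separate these.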